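Methyl on the phenyl ring of compound 1

A few compounds are considered here, and "the series" means these few. Any claim that something is new, unique, unknown or untested is made for them only; others in the source may bear on it.

Compound 1 `O=C1C2=C(C(=O)c3ncccc31)C1(CS2)NC(=O)N(c2ccccc2)C1=O` holds the lowest number of the three measured compounds in a functional assay on CCRF-SB cells (Homo sapiens) for antiproliferative activity, read by MTT assay, with a stated time of 96 h (on this read-out higher numbers stand for weaker inhibition and lower numbers for stronger inhibition), where compound 1 gives 30 nM. Compound 2 `Cc1ccc(N2NC(=O)NC3(CSC4=C3C(=O)c3ncccc3C4=O)C2=O)cc1` stands nearest with 37 nM, a gap within the scatter; compound 3 `O=C1NC(=O)C2(CSC3=C2C(=O)c2ncccc2C3=O)N1` is furthest with 150 nM. Within the data shown here, the one step between single-change neighbours, a 5.0-fold higher number from compound 1 to compound 3 (0.70 log units; beyond the scatter), shows that removing the whole phenyl weakens inhibition modestly.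

Compound 4 `Cc1ccc(N2C(=O)NC3(CSC4=C3C(=O)c3ncccc3C4=O)C2=O)cc1` differs from compound 1 by methyl in place of hydrogen on an aromatic carbon, so the phenyl becomes 4-methylphenyl, the methyl sitting para to a large group. Among the measured compounds shown here, no measured pair isolates this change. The phenyl itself matters, as compound 3 shows, but the values of compound 1 and compound 2 suggest that a 4-methylphenyl attached to the core is tolerated, though compound 2 is not a single-change neighbour of either. Hence no step beyond the scatter is expected from compound 1 to compound 4 in this assay, no change at the digits printed from compound 1 to compound 4 (within the scatter), and compound 4 is estimated at 30 nM, within 12 nM to 75 nM.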

Compound 4, half-maximal inhibitory concentration: 20 nM
For compound 4 the middle estimate is 1.5-fold (0.18 log units) above the measured one; low and high end bracket the measured number.
By their numbers in this assay, from the lowest: compounds 4, 1 and 2 (each within the scatter of the next); then compound 3.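

The position para to a large group on the phenyl ring of compound 1 accepts a methyl without a change that can be read: the step is a 1.5-fold lower number from compound 1 to compound 4 (0.18 log units; within the scatter). The aryl group on the ring nitrogen also keeps its value in the 4-methylphenyl form, with a 7.5-fold lower number from compound 3 to compound 4 (0.88 log units; beyond the scatter), so the gain over hydrogen seen with phenyl is not lost when this carbon carries a methyl. No measurement at hand bears on why the methyl leaves the number within the scatter.

Open, from the compounds shown here alone, is whether this carbon also accepts a group other than methyl, such as a methoxy, an amine or a carboxylic acid, or a longer chain such as butyl. The compounds shown also leave open how a methyl behaves on the other carbons of this phenyl ring.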